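The source may hold more compounds than are shown below. What is called first, only, known or untested is meant among the compounds shown, and "the series" means these compounds.

In an ADME assay on C8166 cells (Homo sapiens) for cytotoxicity (on this read-out lower numbers stand for higher toxicity in this test and higher numbers for lower toxicity in this test), compound 1 `CCN1C(=O)N(c2ccccc2)C(=O)N(c2ccccc2)c2cc(C(F)(F)F)ccc21` reports only a limit, > 4000 nM. Compound 2 `CCN1C(=O)N(c2cccc(OC)c2)C(=O)N(c2ccccc2)c2cc(C(F)(F)F)ccc21` also reports only a limit, > 20000 nM. Compound 3 `CCN1C(=O)N(c2ccc(OC)cc2)C(=O)N(c2ccccc2)c2cc(C(F)(F)F)ccc21` differs from compound 1 by methoxy in place of hydrogen on an aromatic carbon, phenyl to 4-methoxyphenyl. Among the compounds with values here, the one measured step bearing on this change, a step that the two limits leave unreadable from compound 1 to compound 2, is the same kind of methoxy in place of hydrogen on an aromatic carbon, but its size stays unknown. Only a modest drift toward higher numbers in this assay is therefore expected. For compound 3, the estimated step is a step that the limit leaves unreadable from compound 1 to compound 3. Compound 3 is expected to give 25000 nM, with an estimated range of 6000 nM to 100000 nM.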

Compound 3, half-maximal cytotoxic concentration: > 16000 nM
Compound 3: a limit, no number (the forecaster's own chance of this, stated with the estimate: 70%); the middle value does not contradict the limit.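

Within the data shown here, compound 1, compound 2 and compound 3 all report only limits, so no step among them can be read in this assay. The compounds shown leave open whether methoxy in place of hydrogen changes the half-maximal cytotoxic concentration at all, and by how much.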